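Swapping the Ring on the Amide Nitrogen

The source may report more compounds than this note shows. Statements on the series, on what has been measured and on what is new or still open speak of the compounds shown alone.

In a functional assay on HOS-TE85 cells (Homo sapiens) for inhibition, read by CCK-8 assay, with a stated time of 72 h (a higher number here means a weaker inhibitor, a lower number a stronger inhibitor), compound 3 `O=C(NCCCCc1ccccc1)c1cc(F)cc(C2SCC(=O)N2c2ccccn2)c1` gives 14.2 nM, the lowest of the two numbers shown. Compound 2 `C#Cc1cc(C(=O)NCCCCc2ccccc2)cc(C2SCC(=O)N2c2ccccc2OC)c1` gives 40.8 nM, a gap beyond the usual scatter. Compound 1 `COc1ccccc1N1C(=O)CSC1c1cc(F)cc(C(=O)O)c1` gives only a limit, > 1000 nM, rather than a number. That reading is the limit of > 1000 nM in this assay, at which 1 of the 3 values shown sits. Compound 4 `COc1ccccc1N1C(=O)CSC1c1cc(F)cc(C(=O)NCCCCc2ccccc2)c1` has not yet been measured. It differs from compound 3 in one place: 2-methoxyphenyl in place of pyridin-2-yl on an amide-type nitrogen in a ring. Going by the values given here, no measured pair isolates this change, so its direction is open; compound 2, which also carries 2-methoxyphenyl, gives 40.8 nM, though its other group differs from that of compound 3 as well. A modest step toward a weaker inhibitor is expected, a 2.1-fold higher number from compound 3 to compound 4 (0.32 log units; beyond the scatter). Compound 4 is therefore estimated at 30 nM, within 8 nM to 120 nM.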

Compound 4, half-maximal inhibitory concentration: 40.9 nM
Estimate against measurement, compound 4: 1.4-fold (0.13 log units) below, and the stated range covers the measured number.
By their numbers in this assay, from the lowest: compound 3; then compounds 2 and 4 (each within the scatter of the next). At a limit, above all of these: compound 1.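

In this assay the ring substituent on the amide-type nitrogen now has a direct comparison, a 2.9-fold higher number from compound 3 to compound 4 (0.46 log units; beyond the scatter), with pyridin-2-yl giving the stronger inhibitor. With 2-methoxyphenyl on that nitrogen, the aromatic carbon's substituent makes no measurable difference, a 1.0-fold higher number from compound 2 to compound 4 (0.00 log units; within the scatter), when fluoro replaces ethynyl. The step of an at least 24-fold lower number from compound 1 to compound 4 (1.38 log units; beyond the scatter) starts from a limit rather than a number: the limit of > 1000 nM in this assay, at which 1 of the 4 values shown sits.

On these data alone, whether pyridin-2-yl would keep its advantage alongside ethynyl remains open. So does how plain phenyl on that nitrogen, or a shorter chain than 4-phenylbutyl on the amide, would read.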